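The compounds below may be only part of what the source reports. "The series", "measured", "known", "first", "only" and "open" are said of these compounds alone.

In a physicochemical assay for solubility, read by nephelometry, at pH 7.4 (on this read-out lower numbers stand for lower solubility and higher numbers for higher solubility), compound 1, whose structure is `COc1cccc(NC(=O)c2nnn(CC3CCNCC3)c2N)c1`, gives > 250000 nM, and that number is a limit of the assay rather than a measured value. Among the three values shown, compound 1 is the one that sits at the limit of > 250000 nM in this assay, at which 1 of the 3 values shown sits. The unmeasured compound 4, with structure `COc1cccc(NC(=O)c2nnn(Cc3ccc(C#N)cc3)c2N)c1`, differs from compound 1 in one place: 4-cyanophenyl in place of piperidin-4-yl on a saturated chain carbon bound to an aromatic nitrogen.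

Two measured compounds carry a substituted phenyl group at that same place. Compound 2, structure `COc1cccc(NC(=O)c2nnn(Cc3ccc(OC(F)(F)F)cc3)c2N)c1`, gives 12000 nM in this assay, and compound 3, structure `COc1cccc(NC(=O)c2nnn(Cc3ccc(C(C)C)cc3)c2N)c1`, gives 14000 nM. The step of an at least 17-fold lower number from compound 1 to compound 3 (1.25 log units; beyond the scatter) is the one that most resembles the change toward compound 4, since both swap the piperidin-4-yl group for a substituted phenyl. The step of a 1.2-fold higher number from compound 2 to compound 3 (0.07 log units; within the scatter) shows that changing the substituent on that phenyl made little difference here.

A large fall in solubility is therefore expected for compound 4, of about an at least 12-fold lower number from compound 1 to compound 4 (1.09 log units; beyond the scatter). The estimate for compound 4 in this assay is 20000 nM, with a range from 7000 nM to 60000 nM.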

Compound 4, solubility: 216000 nM
Estimate against measurement, compound 4: 11-fold (1.03 log units) below, and the stated range ends below it.
By their numbers in this assay, from the lowest: compounds 2 and 3 (each within the scatter of the next); then compound 4. At a limit, above all of these: compound 1.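

In this assay, the group on the phenyl ring now matters: the earlier swap of trifluoromethoxy for isopropyl stayed within the scatter, yet cyano gives a 15-fold higher number from compound 3 to compound 4 (1.19 log units; beyond the scatter) and an 18-fold higher number from compound 2 to compound 4 (1.26 log units; beyond the scatter). A substituted phenyl in place of piperidin-4-yl on this saturated chain carbon therefore need not bring a large fall, as an at least 1.1-fold lower number from compound 1 to compound 4 (0.06 log units; that floor lies within the scatter) shows, although the same kind of swap did bring one for compound 3. The reading for compound 1 is a limit and not a number, so the true size of that step stays unknown: the limit of > 250000 nM in this assay, at which 1 of the 4 values shown sits.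

The compounds shown cannot tell why cyano stands so far from isopropyl and trifluoromethoxy. Going by these compounds, whether an amine or a carboxylic acid on that aromatic carbon would give a number closer to compound 4 or to compound 3 remains open.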